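The source may hold more compounds than are shown below. What is called first, only, known or untested is meant among the compounds shown, and "the series" means these compounds.

Working notes on the series. Compound 1 `C=C1CC[C@@H]2[C@](C)(CCC[C@]2(C)C(=O)O)[C@H]1CC/C(C)=C/CO` in a functional assay on HT-1080 cells (Homo sapiens) for cytotoxicity, read by MTT assay, with a stated time of 24 h (a higher number here means that more compound is needed for the effect, a lower number that less compound is needed), gives 72.9 ug/mL. Compound 2 `C=C1CC[C@@H]2[C@](C)(CCC[C@]2(C)C(=O)O)[C@H]1CC/C(C)=C/C(=O)OC` in this assay gives 72.8 ug/mL; the step of a 1.0-fold lower number from compound 1 to compound 2 (0.00 log units; within the scatter) shows compound 1 and compound 2 sitting within the scatter of each other. Compound 3 `C=C[C@](C)(O)CC[C@H]1C(=C)CC[C@@H]2[C@]1(C)CCC[C@]2(C)C(=O)O` is not yet measured in this assay; relative to compound 1 the change is 1-hydroxy-1-methylprop-2-en-1-yl in place of 3-hydroxy-1-methylprop-1-en-1-yl on a saturated chain carbon, two bonds along the chain from a saturated ring carbon. The only measured step, a 1.0-fold lower number from compound 1 to compound 2 (0.00 log units; within the scatter), touched a different group and stayed within the scatter, so nothing shown points to a change beyond the scatter. Compound 3 is therefore expected to give 70 ug/mL, with a range of 30 ug/mL to 160 ug/mL, a step of a 1.0-fold lower number from compound 1 to compound 3 (0.02 log units; within the scatter).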

Compound 3, concentration for half-maximal effect: 94.9 ug/mL
Compound 3: the middle estimate sits 1.4-fold (0.13 log units) below what was measured, and the stated range covers the measured number.
By their numbers in this assay, from the lowest: compounds 2, 1 and 3 (each within the scatter of the next).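

Swapping 3-hydroxy-1-methylprop-1-en-1-yl for 1-hydroxy-1-methylprop-2-en-1-yl, the same atoms joined differently, gives a 1.3-fold higher number from compound 1 to compound 3 (0.11 log units; within the scatter), and the comparison with the methyl ester gives a 1.3-fold higher number from compound 2 to compound 3 (0.12 log units; within the scatter). The three groups on this saturated chain carbon, including the first one with a defined stereocentre, thus all lie within the scatter in this assay. Nothing on hand bears on why these numbers stay so close. Going by these compounds, whether an amine or a longer chain at this place would give a step beyond the scatter stays open. On these data alone, the other stereocentre arrangement of 1-hydroxy-1-methylprop-2-en-1-yl also stays open.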